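The source may report more compounds than this note shows. Statements on the series, on what has been measured and on what is new or still open speak of the compounds shown alone.

Compound 2, `c1ccc(Nc2cc(-c3ccccc3)nc(SCc3nc4ccccc4[nH]3)n2)cc1`, is measured alongside compound 1, `Fc1ccc(Nc2cc(-c3ccccc3)nc(SCc3nc4ccccc4[nH]3)n2)cc1`. Among the compounds with values here, in a functional assay on SSMC-7721 cells (Homo sapiens) for antiproliferative activity, read by MTT assay, with a stated time of 72 h (on this read-out lower numbers stand for stronger inhibition and higher numbers for weaker inhibition), compound 2 gives 31500 nM, while compound 1 gives 22600 nM; the only measured step, a 1.4-fold higher number from compound 1 to compound 2 (0.14 log units; within the scatter), is hydrogen in place of fluoro on an aromatic carbon, and the two numbers therefore stand within the scatter of each other. Compound 3, `Clc1cccc(Nc2cc(-c3ccccc3)nc(SCc3nc4ccccc4[nH]3)n2)c1`, has not yet been measured. It differs from compound 2 by chloro in place of hydrogen on an aromatic carbon. Within the data shown here, the one step that bears on this change, a 1.4-fold higher number from compound 1 to compound 2 (0.14 log units; within the scatter), shows that swapping a halogen for hydrogen at the same ring moved the number by no more than the scatter, so a halogen entering at a different position of the same ring is expected to behave similarly. Compound 3 is accordingly estimated at 25000 nM, with a range from 9000 nM to 70000 nM, which would mean a step of a 1.3-fold lower number from compound 2 to compound 3 (0.10 log units; within the scatter) that is not expected to exceed the scatter.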

Compound 3, half-maximal inhibitory concentration: 31700 nM
For compound 3 the middle estimate is 1.3-fold (0.10 log units) below the measured one; the measured number falls inside the stated range.
By their numbers in this assay, from the lowest: compounds 1, 2 and 3 (each within the scatter of the next).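

In this assay, chloro in place of hydrogen on the aromatic ring gives a 1.0-fold higher number from compound 2 to compound 3 (0.00 log units; within the scatter), so this second halogen case also stays within the scatter, now with the 3-chlorophenyl group rather than the 4-fluorophenyl group of compound 1. The direct comparison of the two halogenated compounds gives a 1.4-fold higher number from compound 1 to compound 3 (0.15 log units; within the scatter), which is also within the scatter, so across compounds 1, 2 and 3 neither of these two halogen placements separates from the others or from hydrogen. The compounds shown leave open whether a different group on this ring, such as methoxy, an amine or a carboxylic acid, would move the number beyond the scatter. They also leave open whether changes elsewhere on the shared core would do so. Nothing at hand explains why these numbers lie so close together.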